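Moving the methoxy group: what to expect for compound 4

The source may report more compounds than this note shows. Statements on the series, on what has been measured and on what is new or still open speak of the compounds shown alone.

Compound 1 `O=C1NCCN1c1ccc(S(=O)(=O)Nc2cccc(Br)c2)cc1`: 100 nM
Compound 2 `O=C1NCCN1c1ccc(S(=O)(=O)Nc2ccc(F)c(F)c2)cc1`: 620 nM
Compound 3 `COc1ccccc1NS(=O)(=O)c1ccc(N2CCNC2=O)cc1`: 770 nM

In a functional assay on MCF7 cells (Homo sapiens) for antiproliferative activity, read by sulforhodamine B assay, with a stated time of 48 h (a higher number here means a weaker inhibitor, a lower number a stronger inhibitor), compound 3 gives the highest of the three numbers. Its nearest neighbour is compound 2, and the step of a 1.2-fold higher number from compound 2 to compound 3 (0.09 log units; within the scatter) lies within the scatter. The step of a 7.7-fold higher number from compound 1 to compound 3 (0.89 log units; beyond the scatter) lies beyond it. Compound 4 `COc1cccc(NS(=O)(=O)c2ccc(N3CCNC3=O)cc2)c1` differs from compound 3 by 3-methoxyphenyl in place of 2-methoxyphenyl on a sulfonamide nitrogen. Among the measured compounds shown here, no measured step moves a methoxy group from one position to another; the steps that exist, a 6.2-fold higher number from compound 1 to compound 2 (0.79 log units; beyond the scatter) and a 7.7-fold higher number from compound 1 to compound 3 (0.89 log units; beyond the scatter), exchange the whole aryl group and show that the ring substitution pattern shifts the number modestly. Since the 3-bromophenyl of compound 1 gives 100 nM, a modest step downward is expected for compound 4: a 1.9-fold lower number from compound 3 to compound 4 (0.28 log units; within the scatter). Compound 4 is estimated at 400 nM, with a range from 150 nM to 1200 nM.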

Compound 4, half-maximal inhibitory concentration: 120 nM
For compound 4 the middle estimate is 3.3-fold (0.52 log units) above the measured one; the measured number lies below the stated range.
By their numbers in this assay, from the lowest: compounds 1 and 4 (each within the scatter of the next); then compounds 2 and 3 (each within the scatter of the next).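

In this assay, among the compounds shown here, shifting the methoxy group alone, from the 2-methoxyphenyl to the 3-methoxyphenyl on the sulfonamide nitrogen, gives a 6.4-fold lower number from compound 3 to compound 4 (0.81 log units; beyond the scatter), so the group's position matters even with the same atoms, whereas the earlier steps exchanged the whole aryl group. The 3-methoxyphenyl also separates from the 3,4-difluorophenyl, with a 5.2-fold lower number from compound 2 to compound 4 (0.71 log units; beyond the scatter), while methoxy in place of bromo gives only a 1.2-fold higher number from compound 1 to compound 4 (0.08 log units; within the scatter). Nothing measured here explains these differences. Open, on these data alone, is whether an ethoxy group, a hydroxyl group or an amine in place of the methoxy of compound 4 would keep its number.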